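Aryl hydrazones on a shared core: from iodine to methoxy

The source may report more compounds than this note shows. Statements on the series, on what has been measured and on what is new or still open speak of the compounds shown alone.

Three compounds built on one shared core, each carrying a differently substituted phenyl group on an amine nitrogen, have been measured in a functional assay on the whole organism for inhibition, with Rattus norvegicus as the target; on this read-out higher numbers stand for an effect only at larger amounts of compound and lower numbers for an effect already at smaller amounts. Compound 1 `CC1CC/C(=N\Nc2ccccc2F)c2ncc(C(=O)O)c(=O)n21` reaches only a limit of the assay, not a number: in this assay compound 1 gives > 1000 umol/kg. Compound 2 `CC1CC/C(=N\Nc2ccccc2Br)c2ncc(C(=O)O)c(=O)n21` likewise ends at a limit of the assay; in this assay compound 2 gives > 320 umol/kg. Among the compounds with values here, compound 3 `CC1CC/C(=N\Nc2cccc(I)c2)c2ncc(C(=O)O)c(=O)n21` is the single compound with a measured number, since in this assay compound 3 gives 1000 umol/kg. The steps between the three stay unreadable: a step that the two limits leave unreadable from compound 1 to compound 2, a number no higher from compound 1 to compound 3 (the limit leaves the size open), and a step that the limit leaves unreadable from compound 2 to compound 3. This rests on the limit of > 1000 umol/kg in this assay, at which 1 of the 3 values shown sits, and on (the limit of > 320 umol/kg in this assay, at which 1 of the 3 values shown sits).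

Compound 4 `COc1ccc(N/N=C2\CCC(C)n3c2ncc(C(=O)O)c3=O)cc1` has not yet been measured. It differs from compound 3 in one place: 4-methoxyphenyl in place of 3-iodophenyl on an amine nitrogen. Each of the measured steps involves a limit; none of them tells the direction or size that such a change would bring. With no readable step to lean on, compound 4 is expected to sit close to compound 3, with a wide range and a real chance that this assay again reports only a limit. The step is therefore estimated as no change at the digits printed from compound 3 to compound 4 (within the scatter). For compound 4 the estimated value in this assay is 1000 umol/kg, expected to fall between 300 umol/kg and 3000 umol/kg.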

Compound 4, dose for 50% inhibition: 7.6 umol/kg
Beside the measured number, compound 4's estimate is 130-fold (2.12 log units) above it; measured number outside the range, below it.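

Within the data shown here, the aryl group on the amine nitrogen now proves able to shift the result in this assay by a wide margin: 4-methoxyphenyl in place of 3-iodophenyl gives a 130-fold lower number from compound 3 to compound 4 (2.12 log units; beyond the scatter), the first step in this set with a readable size, since it joins two measured numbers. Compound 4 also stands clearly apart from the compounds carrying 2-bromophenyl and 2-fluorophenyl, with an at least 42-fold lower number from compound 2 to compound 4 (1.62 log units; beyond the scatter) and an at least 130-fold lower number from compound 1 to compound 4 (2.11 log units; beyond the scatter). Both of those steps start from a limit of the assay, not from a number: the limit of > 1000 umol/kg in this assay, at which 1 of the 4 values shown sits, and the limit of > 320 umol/kg in this assay, at which 1 of the 4 values shown sits.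

The compounds shown leave open whether the lower number belongs to the methoxy group itself or to where it sits on the ring, as 3-iodophenyl and 4-methoxyphenyl differ in both the group and its place. They also do not tell how a 3-methoxyphenyl group, a 4-ethoxyphenyl group with its longer chain, or a phenyl ring carrying an amine would read in this assay.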